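A few compounds are considered here, and "the series" means these few. Any claim that something is new, unique, unknown or untested is made for them only; others in the source may bear on it.

Compounds measured in a functional assay on SW-620 cells (Homo sapiens) for inhibition; a higher number here means a weaker inhibitor, a lower number a stronger inhibitor:

compound 1 `CCC(C)C1NC(=O)N(C2CCCCC2)C1=O` gives > 100000 nM, which is a limit of the assay and not a number.
compound 2 `CCC(C)C1NC(=O)N(C2CCCC2)C1=O` gives > 100000 nM, likewise a limit of the assay.
compound 3 `CC(C)C1NC(=O)N(C2CCCC2)C1=O` gives > 100000 nM, again a limit of the assay.

Compound 1 and compound 2 differ in their cores; the difference between the two cores is not broken down here. Compound 2 and compound 3 share a core and differ by hydrogen in place of methyl on a saturated chain carbon, two bonds along the chain from a saturated ring carbon. The step that the two limits leave unreadable from compound 2 to compound 3 cannot be sized, because the limit of > 100000 nM in this assay, at which 3 of the 3 values shown sit, holds both ends of it.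

The unmeasured compound 4 `CC(C)C1NC(=O)N(C2CCCCC2)C1=O` carries the core of compound 1 and differs from it by hydrogen in place of methyl on a saturated chain carbon, two bonds along the chain from a saturated ring carbon. This is the same change as that from compound 2 to compound 3, made in the same place word for word, only on the other core.

For this assay the step from compound 1 to compound 4 is expected to be a step that the limit leaves unreadable from compound 1 to compound 4, that is, no readable movement; this rests on compound 1 standing at the limit of > 100000 nM in this assay, at which 3 of the 3 values shown sit, and on the matching pair compound 2 to compound 3 standing there as well. Compound 4 is therefore estimated at 150000 nM, within a range from 50000 nM to 1000000 nM, and the most likely outcome is that this assay again reports only a limit for compound 4 rather than a number.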

Compound 4, half-maximal inhibitory concentration: > 100000 nM
Compound 4: no number, only a limit; the forecaster's own chance of this, stated with the estimate: 85%; the middle value lies beyond the limit too.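

In this assay compound 4 gives > 100000 nM as a limit of the assay and not a number. No step can be read from compound 1 to compound 4 because both ends rest on a limit: the limit of > 100000 nM in this assay, at which 4 of the 4 values shown sit.

The compounds shown leave open how far the change from sec-butyl to isopropyl moves inhibition on either core, and whether any compound of this series reaches a readable value in this assay at all.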